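Demethylation of the Aryl Ether in a Thiazole Amide Series

The compounds below may be only part of what the source reports. "The series", "measured", "known", "first", "only" and "open" are said of these compounds alone.

For the measured compounds named here, compound 1 `COc1ccc(-c2cnc(NC(=O)CCCCCCNC(=O)C(O)(O)C(F)(F)F)s2)cc1` is the only compound here with a numerical reading: in a functional assay on HCT-116 cells (Homo sapiens) for inhibition, read by colorimetric assay, with a stated time of 3 days (on this read-out higher numbers stand for weaker inhibition and lower numbers for stronger inhibition), compound 1 gives 930 nM. Compound 2 `NC(=O)C(=O)NCCCCCCCC(=O)Nc1ccccc1` reaches only a limit of this assay, > 100000 nM, which is the limit of > 100000 nM in this assay, at which 1 of the 2 values shown sits. Compound 3 `O=C(CCCCCCNC(=O)C(O)(O)C(F)(F)F)Nc1ncc(-c2ccc(O)cc2)s1` differs from compound 1 by hydrogen in place of methyl on an oxygen on an aromatic ring. Going by the values given here, no step between measured compounds is available here, and the change is small, so the expected step of a 1.3-fold higher number from compound 1 to compound 3 (0.11 log units; within the scatter) is estimated to stay within the usual scatter of this assay, with no clear direction. Compound 3 is therefore expected to read 1200 nM, between 300 nM and 5000 nM.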

Compound 3, half-maximal inhibitory concentration: 1020 nM
Estimate against measurement, compound 3: 1.2-fold (0.07 log units) above, within the range that was stated.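

In this assay, 4-methoxyphenyl gives way to 4-hydroxyphenyl with a 1.1-fold higher number from compound 1 to compound 3 (0.04 log units; within the scatter), so the methyl on this oxygen can be lost without a reading that stands apart from the scatter. Methoxy and hydroxy thus read alike at this place on the aromatic ring. Nothing given here bears on why this is so.

From the compounds shown here alone, whether an amine or a carboxylic acid in this place would also read alike remains open. So does whether this match would hold with a longer chain on the core of compound 1.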